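Working notes: one ester change from compound 2

A few compounds are considered here, and "the series" means these few. Any claim that something is new, unique, unknown or untested is made for them only; others in the source may bear on it.

Of the compounds shown here, two have numbers so far, and they share a core. In a functional assay on PA-1 cells (Homo sapiens) for cytotoxicity, read by colony formation (on this read-out lower numbers stand for stronger inhibition and higher numbers for weaker inhibition), compound 1 (`COC(=O)C1=CO[C@@H](O[C@@H]2O[C@H](COC(c3ccccc3)(c3ccccc3)c3ccccc3)[C@@H](OC(=O)O)[C@H](OC(C)=O)[C@H]2OC(C)=O)[C@@H]2[C@@H](C)[C@@H](OC(C)=O)C[C@H]12`) gives 1.2 ug/mL as its value, and compound 2 (`CCC(=O)OC[C@H]1O[C@@H](O[C@@H]2OC=C(C(=O)OC)[C@H]3C[C@H](OC(C)=O)[C@H](C)[C@@H]23)[C@H](OC(C)=O)[C@@H](OC(C)=O)[C@@H]1OC(C)=O`) gives 2.85 ug/mL as its value. Compound 2 therefore holds the higher number of the pair, meaning the weaker inhibition, and its gap to compound 1 lies beyond the usual scatter. These two compounds differ in more than one place, so that gap does not size any single change.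

Compound 3 (`COC(=O)C1=CO[C@@H](O[C@@H]2O[C@H](COC(=O)C=C(C)C)[C@@H](OC(C)=O)[C@H](OC(C)=O)[C@H]2OC(C)=O)[C@@H]2[C@@H](C)[C@@H](OC(C)=O)C[C@H]12`) departs from compound 2 in one place, on a carbonyl carbon: (2-methylprop-1-en-1-yl in place of ethyl on a carbonyl carbon). In words, propanoyl gives way to (2-methylprop-1-en-1-yl)carbonyl. Among the measured compounds shown here, no measured single-place step exists to size this swap, so the expectation stays anchored on compound 2 at (2.85 ug/mL). No step beyond the scatter is expected in this assay, and no direction is favoured, so the expected change is small (a 1.1-fold lower number from compound 2 to compound 3 (0.06 log units; within the scatter)). Compound 3 is estimated at 2.5 ug/mL as a middle value, with an expected range of (1.1 ug/mL to 5.5 ug/mL).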

Compound 3, half-maximal inhibitory concentration: 1.84 ug/mL
Compound 3: the middle estimate sits 1.4-fold (0.13 log units) above what was measured; low and high end bracket the measured number.
By their numbers in this assay, from the lowest: compounds 1, 3 and 2 (each within the scatter of the next, the first and the last beyond it).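

Working notes: the step at the carbonyl carbon

Among the compounds shown here, this is the first step that sizes a change in one place: in this assay, putting 2-methylprop-1-en-1-yl in place of ethyl on a carbonyl carbon gives a 1.5-fold lower number from compound 2 to compound 3 (0.19 log units; within the scatter) and so stays within the scatter. Propanoyl and (2-methylprop-1-en-1-yl)carbonyl therefore cannot be told apart on this read-out, and for this pair the added carbons and the double bond outside aromatic rings leave no readable mark. Nothing available on these compounds speaks to why the read-out holds across this swap.

For the compounds shown here, whether a longer saturated chain, a phenyl ring or an amine on this carbonyl carbon would move the number beyond the scatter stays open, since a single step shows only that this one swap leaves the number within it. Also open, as far as these compounds go, is whether the same swap would read alike on the trityl-bearing background of compound 1, which differs from compound 2 in more than one place.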